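Swapping cyclohexylmethyl for cyclohexyl on the shared core

The source may hold more compounds than are shown below. What is called first, only, known or untested is meant among the compounds shown, and "the series" means these compounds.

Measured so far:
compound 1, `Fc1ccc(-c2ccc3c(NCCCNCc4ccco4)ccnc3c2)cc1`: 9.47
compound 2, `c1coc(CNCCCNc2ccnc3cc(CC4CCCCC4)ccc23)c1`: 9.47

In a physicochemical assay for acid dissociation, compound 1 gives 9.47. Compound 2 gives 9.47 in this assay, level with compound 1 at the digits shown; the single known step is no change at the digits printed from compound 1 to compound 2 (within the scatter). Compound 3, `c1coc(CNCCCNc2ccnc3cc(C4CCCCC4)ccc23)c1`, differs from compound 2 by cyclohexyl in place of cyclohexylmethyl on an aromatic carbon. That one step bears on the change: a larger swap at the same place left the value unmoved, so no step beyond the scatter is expected here, no change at the digits printed from compound 2 to compound 3 (within the scatter). Compound 3 is therefore estimated at 9.47, between 9.1 and 9.8.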

Compound 3, acid dissociation constant: 9.47
Compound 3: middle estimate and measured number agree at the digits printed; the range from low to high includes it.
By their numbers in this assay, from the lowest: compounds 1, 2 and 3 (each within the scatter of the next).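

In this assay, cyclohexyl in place of cyclohexylmethyl on this aromatic carbon gives no change at the digits printed from compound 2 to compound 3 (within the scatter), so the ring attached directly reads the same as the one carried on cyclohexylmethyl. Cyclohexyl in place of 4-fluorophenyl gives no change at the digits printed from compound 1 to compound 3 (within the scatter), which leaves all three groups at this position level with one another. Nothing available offers a reason for this reading. Whether an amine or a carboxylic acid on this aromatic carbon would also leave the value level stays open, and the compounds shown do not address changes elsewhere on the shared core.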